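The compounds below may be only part of what the source reports. "The series", "measured", "known", "first", "only" and "open" are said of these compounds alone.

Of the compounds shown here, three built on a shared core have been tested in a functional assay on HT-29 cells (Homo sapiens) for cytotoxicity, read by MTT assay, with a stated time of 6 days; a lower number here means that less compound is needed, a higher number that more compound is needed for the effect. Compound 1 (`COC(=O)c1c(-c2cc(OC)cc(OC)c2)oc2ccccc2c1=O`) gives 6.99 ug/mL. Compound 2 (`COC(=O)c1c(-c2ccc(Br)cc2)oc2ccccc2c1=O`) gives > 25 ug/mL, which is a limit of the assay and not a number. Compound 3 (`COc1cc(-c2oc3ccccc3c(=O)c2C(=O)O)cc(OC)c1OC`) gives > 25 ug/mL, also a limit and not a number. Compound 3 therefore has no exact reading and stands at the limit of > 25 ug/mL in this assay, at which 2 of the 3 values shown sit.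

Compound 4 (`COc1cc(OC)cc(-c2oc3ccccc3c(=O)c2C(=O)O)c1`) differs from compound 3 by hydrogen in place of methoxy on an aromatic carbon, ortho to two methoxy groups and para to a large group: hydrogen in place of methoxy on an aromatic carbon. Among the compounds with values here, no two measured compounds differ in one place, so the data offer no direct gauge of this change in this assay. The expectation therefore starts from compound 3 and its limit of > 25 ug/mL. No change beyond the scatter is expected, and no direction is favoured, so the estimated step is a number no higher from compound 3 to compound 4 (the limit leaves the size open). A report of only a limit is the likeliest outcome. For compound 4 the estimated value is 25 ug/mL, with an expected range of 10 ug/mL to 60 ug/mL.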

Compound 4, concentration for half-maximal effect: > 25 ug/mL
Compound 4 gave a limit, no number; the forecaster's own chance of this, stated with the estimate: 65%; the middle value lies on the limit itself.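

Within the data shown here, compound 4 supplies the first one-place comparison that can be read: with the two methoxy groups kept, hydrogen in place of methyl on an oxygen next to a carbonyl group gives an at least 3.5-fold higher number from compound 1 to compound 4 (0.55 log units; beyond the scatter) in this assay, so the methyl on that oxygen matters for this read-out. The step for hydrogen in place of methoxy cannot be read, as compound 3 and compound 4 are both reported only as limits, and nothing can be said about that position while the free acid is present. Most of the series now rests on a single limit: the limit of > 25 ug/mL in this assay, at which 3 of the 4 values shown sit.

On these data alone, it remains open whether removing that methoxy group would change the number when the methyl stays on the oxygen. As far as these compounds go, it is also open whether an amide or an ethyl ester in that place would keep a readable value.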